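Side-chain change from compound 2 to compound 4

The compounds below may be only part of what the source reports. "The series", "measured", "known", "first", "only" and "open" are said of these compounds alone.

- compound 1 `COCc1nc2nc(C)cc(Nc3ccc(C(F)(F)F)cc3)n2n1` gives 75.6%
- compound 2 `COCCc1nc2nc(C)cc(Nc3ccc(S(F)(F)(F)(F)F)cc3)n2n1` gives 87.7%
- compound 3 `CCc1nc2nc(C)cc(Nc3cccc(Cl)c3)n2n1` gives 86.7%

In an ADME assay on a cell-free system (plasma, Homo sapiens) for protein binding, compound 2 gives 87.7% and lies within the scatter of both compound 1 and compound 3, so these three values do not separate. Compound 4 `Cc1cc(Nc2ccc(S(F)(F)(F)(F)F)cc2)n2nc(C(C)(F)F)nc2n1` departs from compound 2 1,1-difluoroethyl in place of 2-methoxyethyl on an aromatic carbon with 1,1-difluoroethyl in place of 2-methoxyethyl on an aromatic carbon. Within the data shown here, no measured pair isolates this change, so the expectation remains tentative. A small step towards less free compound is expected, estimated as a 1.4-fold lower unbound fraction from compound 2 to compound 4 (0.14 log units; within the scatter) in this assay on this basis. Compound 4 is expected at 91% with a range of 83% to 96% in this estimate.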

Compound 4, plasma protein binding: 97.4%
Beside the measured number, compound 4's estimate is 3.5-fold (0.54 log units) (unbound fraction) above it, outside the stated range (above it).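

In this assay, among these compounds, the change to 1,1-difluoroethyl in place of 2-methoxyethyl on an aromatic carbon gives a 4.7-fold lower unbound fraction from compound 2 to compound 4 (0.67 log units; beyond the scatter) and is the only step in this set that isolates one place. It shows that this position, between two ring nitrogen atoms, can shift binding beyond the scatter with the rest of compound 2 held constant. No measurement available here accounts for the size of this step. Going by these compounds, whether an amine or a carboxylic acid at this position would shift binding the opposite way remains open. A single pair also leaves open whether the step carries over to compounds other than compound 2.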